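Linear heptyl in place of branched chain: forecast for compound 4

A few compounds are considered here, and "the series" means these few. Any claim that something is new, unique, unknown or untested is made for them only; others in the source may bear on it.

Three compounds built on the shared core have numbers in an assay on isolated protein for inhibition of dual specificity calcium/calmodulin-dependent 3',5'-cyclic nucleotide phosphodiesterase 1A (Bos taurus); on this read-out lower numbers stand for stronger inhibition and higher numbers for weaker inhibition. Compound 1 `CCCCCc1nc2c([nH]1)N1C(=N[C@@H]3CCC[C@@H]31)N(C)C2=O` gives 31 nM. Compound 2 `CC(C)CCc1nc2c([nH]1)N1C(=N[C@@H]3CCC[C@@H]31)N(C)C2=O` gives 14 nM. Compound 3 `CCCC(CCC)c1nc2c([nH]1)N1C(=N[C@@H]3CCC[C@@H]31)N(C)C2=O` gives 60 nM, the highest of the three numbers: its nearest neighbour is compound 1, at a 1.9-fold higher number from compound 1 to compound 3 (0.29 log units; within the scatter) and thus within the scatter, and its furthest is compound 2, at a 4.3-fold higher number from compound 2 to compound 3 (0.63 log units; beyond the scatter) and thus beyond the scatter.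

Compound 4 `CCCCCCCc1nc2c([nH]1)N1C(=N[C@@H]3CCC[C@@H]31)N(C)C2=O` carries the change (heptyl in place of 1-propylbutyl on an aromatic carbon); the two compounds have the same atoms, joined differently. Among the measured compounds shown here, two measured steps bear on this. The step of a 1.9-fold higher number from compound 1 to compound 3 (0.29 log units; within the scatter) took a pentyl chain to a 1-propylbutyl group, and the step of a 4.3-fold higher number from compound 2 to compound 3 (0.63 log units; beyond the scatter) took an isopentyl chain to the same group; both raised the number, one within and one beyond the scatter. For the measured compounds named here, compound 4 moves back toward a straight chain while lengthening it, and no measured step covers that lengthening. A modest lowering of the number in this assay is therefore expected, with a wide spread. For compound 4 the expected step is a 2.0-fold lower number from compound 3 to compound 4 (0.30 log units; within the scatter). Compound 4 is estimated at 30 nM, with a range from 10 nM to 90 nM.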

Compound 4, half-maximal inhibitory concentration: 160 nM
For compound 4 the middle estimate is 5.3-fold (0.73 log units) below the measured one; the measured number lies above the stated range.
By their numbers in this assay, from the lowest: compound 2; then compounds 1 and 3 (each within the scatter of the next); then compound 4.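

In this assay, the position on the aromatic carbon of the five-membered ring tells apart two groups made of the same atoms joined differently: heptyl in place of 1-propylbutyl gives a 2.7-fold higher number from compound 3 to compound 4 (0.43 log units; beyond the scatter), so here the straight chain ends up with the higher number. Straight-chain length also counts at this position, since ethyl in place of hydrogen at the chain end gives a 5.2-fold higher number from compound 1 to compound 4 (0.71 log units; beyond the scatter), a rise beyond the scatter that the earlier steps, all among chains of other shapes, could not show. Compound 4 now has the highest number of the set, and the widest gap is an 11-fold higher number from compound 2 to compound 4 (1.06 log units; beyond the scatter), so the substituent alone spans a large range on the shared core, with the isopentyl chain of compound 2 at the low end.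

Nothing in the data shown accounts for these differences. Open, from the compounds shown here alone, is how the number moves with length and chain-end shape: a hexyl chain would test the straight series, a 5-methylhexyl chain would test whether a branched end still holds the number down at greater length, and a terminal amine would test whether the chain must be all carbon.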